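Replacing methoxy with fluoro in compound 2

A few compounds are considered here, and "the series" means these few. Any claim that something is new, unique, unknown or untested is made for them only; others in the source may bear on it.

Compound 1 `CSc1ccc(C2=C(c3ccc(F)c(C)c3)C(=O)N3CCCC3C2)cc1`: 500 nM
Compound 2 `COc1ccc(C2=C(c3ccc(SC)cc3)CC3CCCN3C2=O)cc1`: 5000 nM

In a functional assay on MCF-A cells (Homo sapiens) for cytotoxicity (a lower number here means a stronger inhibitor of growth, a higher number a weaker inhibitor of growth), compound 2 has the higher of the two numbers, 5000 nM, so it is the weaker growth inhibitor of the pair. Compound 3 `CSc1ccc(C2=C(c3ccc(F)cc3)C(=O)N3CCCC3C2)cc1` differs from compound 2 by a single change, fluoro in place of methoxy on an aromatic carbon, para to a large group (fluoro in place of methoxy on an aromatic carbon). Among the measured compounds shown here, only one measured step bears on this: a 10-fold higher number from compound 1 to compound 2 (1.00 log units; beyond the scatter), with 4-methoxyphenyl in place of 4-fluoro-3-methylphenyl. It lies beyond the scatter. Compound 3 removes that 4-methoxyphenyl and carries 4-fluorophenyl, which lacks the methyl of compound 1, and no measurement separates the fluoro from the methyl. A step towards a lower number is therefore expected, probably smaller than the measured one. The expected step is a 5.0-fold lower number from compound 2 to compound 3 (0.70 log units; beyond the scatter). Compound 3 is estimated at 1000 nM, with an expected range of 300 nM to 3500 nM.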

Compound 3, concentration for 50% growth inhibition: 800 nM
Compound 3: the middle estimate sits 1.3-fold (0.10 log units) above what was measured; the range from low to high includes it.
By their numbers in this assay, from the lowest: compounds 1 and 3 (each within the scatter of the next); then compound 2.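

In this assay, the step of a 6.3-fold lower number from compound 2 to compound 3 (0.80 log units; beyond the scatter) isolates fluoro in place of methoxy on the aromatic carbon, a change that the earlier step could not separate from the added methyl. The step of a 1.6-fold higher number from compound 1 to compound 3 (0.20 log units; within the scatter), hydrogen in place of methyl, lies within the scatter, so the methyl makes no readable difference here. Among these three compounds, the difference between the 4-methoxyphenyl and 4-fluoro-3-methylphenyl compounds therefore tracks the exchange of methoxy for fluoro, and no evidence bearing on the reason for this is at hand. The compounds shown leave open whether fluoro itself matters, or whether methoxy is simply unfavourable at this place, since no compound carries hydrogen there. From the compounds shown here alone, how a chloro, hydroxyl or amino group would read on the same carbon also remains unknown.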